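A few compounds are considered here, and "the series" means these few. Any claim that something is new, unique, unknown or untested is made for them only; others in the source may bear on it.

In a functional assay on cells (T-cell line, Homo sapiens) for inhibition (on this read-out lower numbers stand for stronger inhibition and higher numbers for weaker inhibition), compound 1 `COc1ccc(CCCN2CCC(CNC(c3ccccc3)c3ccccc3)CC2)cc1` gives 2800 nM and compound 3 `COc1ccc(CCCN2CCC(COCc3ccccc3)CC2)cc1` gives 2100 nM, two values within the scatter of each other. Compound 3 therefore stands level with compound 1 on the numbers available. Compound 2 `COc1ccc(CCCN2CCC(CO)CC2)cc1` reads > 20000 nM, which is a limit of the assay and not a number. Among the measured compounds shown here, the one measured step is an at least 9.5-fold lower number from compound 2 to compound 3 (0.97 log units; beyond the scatter), and it is the step that installed the benzyl group.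

Compound 4 `COc1ccc(CCCN2CCC(COCc3ccc(Cl)cc3)CC2)cc1` alters that same benzyl group, turning it into 4-chlorobenzyl: chloro in place of hydrogen on an aromatic carbon. For the measured compounds named here, the step to compound 3 bears on this change only indirectly, since no measured compound carries a substituent on this aromatic ring. The data thus give no size for the change, and no step beyond the scatter is expected in this assay. The expected step is a 1.4-fold lower number from compound 3 to compound 4 (0.15 log units; within the scatter), with a slightly lower number as the tentative direction. Compound 4 is estimated at 1500 nM, with an expected range from 500 nM to 4500 nM.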

Compound 4, half-maximal inhibitory concentration: 500 nM
Compound 4: the middle estimate sits 3.0-fold (0.48 log units) above what was measured; the range from low to high includes it.
By their numbers in this assay, from the lowest: compound 4; then compounds 3 and 1 (each within the scatter of the next). At a limit, above all of these: compound 2.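

In this assay, among the compounds shown here, the aromatic ring of the benzyl group proves responsive to substitution, which the earlier compounds, with no substituent on this ring, could not show: chloro in place of hydrogen, para to a large group, gives a 4.2-fold lower number from compound 3 to compound 4 (0.62 log units; beyond the scatter). Taken as a whole, 4-chlorobenzyl in place of hydrogen on the oxygen gives an at least 40-fold lower number from compound 2 to compound 4 (1.60 log units; beyond the scatter). Compound 2 stands at a limit of the assay, so the size of that step is a bound and not a measured difference: the limit of > 20000 nM in this assay, at which 1 of the 4 values shown sits.

From the compounds shown here alone, whether fluoro, methyl, methoxy or a carboxylic acid at this place would give a step like that of chloro stays open. So does whether chloro at another place on the ring, or on a ring of compound 1, would do the same.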